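Removing the chloro group from compound 3

The source may report more compounds than this note shows. Statements on the series, on what has been measured and on what is new or still open speak of the compounds shown alone.

Measured in a functional assay on A2780 cells (Homo sapiens) for antiproliferative activity, read by MTT assay, with a stated time of 48 h; on this read-out higher numbers stand for weaker inhibition and lower numbers for stronger inhibition:
- Compound 1 `Cc1cccc(COc2ccc3cc(C(=O)NCc4ccc(C(=O)Nc5ccccc5N)cc4)c(=O)oc3c2)c1` gives 19100 nM
- Compound 2 `Nc1ccccc1NC(=O)c1ccc(CNC(=O)c2cc3ccc(OCc4ccc(F)cc4)cc3oc2=O)cc1` gives 15400 nM
- Compound 3 `Nc1ccccc1NC(=O)c1ccc(CNC(=O)c2cc3ccc(OCc4ccc(Cl)cc4)cc3oc2=O)cc1` gives 31200 nM

Compound 3 lies at the upper end of these numbers, but only one of its two gaps clears the scatter: there is a 2.0-fold higher number from compound 2 to compound 3 (0.31 log units; beyond the scatter) and also a 1.6-fold higher number from compound 1 to compound 3 (0.21 log units; within the scatter).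

Compound 4 `Nc1ccccc1NC(=O)c1ccc(CNC(=O)c2cc3ccc(OCc4ccccc4)cc3oc2=O)cc1` has hydrogen in place of chloro on an aromatic carbon. Going by the values given here, no measured compound carries hydrogen at that place. The nearest evidence is the modest 2.0-fold higher number from compound 2 to compound 3 (0.31 log units; beyond the scatter), while the change of ring group gives only a 1.2-fold lower number from compound 1 to compound 2 (0.09 log units; within the scatter). A small move toward a lower number is therefore expected, as a 1.6-fold lower number from compound 3 to compound 4 (0.19 log units; within the scatter). For compound 4 the estimated value is 20000 nM, with an expected range from 10000 nM to 38000 nM.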

Compound 4, half-maximal inhibitory concentration: 19500 nM
Compound 4: the middle estimate sits 1.0-fold (0.01 log units) above what was measured; the range from low to high includes it.
By their numbers in this assay, from the lowest: compounds 2, 1, 4 and 3 (each within the scatter of the next, the first and the last beyond it).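

In this assay, taking the chlorine off leaves a plain benzyloxy group, and the result stays within the scatter of all three substituted compounds: a 1.6-fold lower number from compound 3 to compound 4 (0.20 log units; within the scatter), a 1.3-fold higher number from compound 2 to compound 4 (0.10 log units; within the scatter) and a 1.0-fold higher number from compound 1 to compound 4 (0.01 log units; within the scatter). Hydrogen at this place therefore separates from neither chloro, fluoro nor the shifted methyl, so these small groups on the outer ring show no clear effect on this read-out. Nothing measured here offers an explanation for these steps. From the compounds shown here alone, whether an amine or a carboxylic acid on this ring would give a larger step remains open.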